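Epimeric ethynyl nucleosides: where compound 3 stands

The source may report more compounds than this note shows. Statements on the series, on what has been measured and on what is new or still open speak of the compounds shown alone.

Measured in a functional assay on KB cells (Homo sapiens), read by MTT assay; on this read-out higher numbers stand for weaker inhibition and lower numbers for stronger inhibition:
- compound 1 `C#C[C@]1(O)[C@@H](CO)O[C@@H](n2ccc(=O)[nH]c2=O)[C@@H]1O` gives > 350000 nM; 29 nM (2 entries); its two entries do not agree with each other.
- compound 2 `CC[C@@]1(O)[C@@H](CO)O[C@@H](n2ccc(N)nc2=O)[C@@H]1O` gives 258000 nM.
- compound 3 `C#C[C@H]1[C@@H](O)[C@H](n2ccc(=O)[nH]c2=O)O[C@@H]1CO` gives > 350000 nM, which is a limit of the assay and not a number.

Compound 3 stands on a limit only; a further entry for it also carries no single number, so no potency can be read for it at all. The set offers no anchor for its position: compound 1 is spread across (the several entries of compound 1 in this assay, > 350000 nM; 29 nM (2 entries)), two entries that do not agree with each other, and the limit of > 350000 nM in this assay, at which 1 of the 3 values shown sits, marks the edge of the assay rather than a measured strength.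

Compound 4 `C#C[C@@H]1[C@@H](O)[C@H](n2ccc(=O)[nH]c2=O)O[C@@H]1CO` differs from compound 3 by the two compounds have the same atoms and bonds and differ only in configuration as drawn: 1 of 4 stereo elements differ; a stereocentre at a saturated ring carbon is drawn S in compound 3 and R in compound 4. Among the compounds with values here, no pair of measured compounds in this set is separated by a single change, so the size of such a step in this assay has no measured precedent here. A change of configuration at one ring carbon, with no atoms leaving or entering, is expected to move the value little, if at all, beyond the scatter; the step is estimated as a number no higher from compound 3 to compound 4 (the limit leaves the size open). Compound 4 is therefore expected to come out near 350000 nM, in the range 50000 nM to 1000000 nM, with a high chance that it too is reported only as a limit.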

Compound 4, half-maximal inhibitory concentration: > 350000 nM
Compound 4: no number, only a limit (the forecaster's own chance of this, stated with the estimate: 70%); the middle value lies on the limit itself.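

In this assay, compound 3 and compound 4 each carry only a limit of the assay, and no step can be read between them. Still open is whether the configuration at that saturated ring carbon matters at all, and which entry for compound 1 holds: the several entries of compound 1 in this assay, > 350000 nM; 29 nM (2 entries)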